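Extending the Aryl Group: From Compound 2 to Compound 3

The compounds below may be only part of what the source reports. "The series", "measured", "known", "first", "only" and "open" are said of these compounds alone.

Of the compounds shown here, two sharing a common core have been measured in a functional assay on A549 cells (Homo sapiens) for inhibition, read by MTT assay, with a stated time of 48 h; on this read-out lower numbers stand for stronger inhibition and higher numbers for weaker inhibition. Compound 1 `O=C(Cn1cnc2scc(-c3ccc(Cl)cc3)c2c1=O)N/N=C/c1ccc(Cl)c([N+](=O)[O-])c1` gives 20000 nM, and compound 2 `O=C(Cn1cnc2scc(-c3ccccc3)c2c1=O)N/N=C/c1ccc(Cl)c([N+](=O)[O-])c1` gives 16000 nM. Going by the values given here, the only measured step, a 1.3-fold lower number from compound 1 to compound 2 (0.10 log units; within the scatter), puts hydrogen in place of chloro on an aromatic carbon and leaves the read-out essentially unchanged. Compound 2 therefore holds the lowest of the two numbers, yet its gap to compound 1 lies within the scatter, so no order between them can be claimed. Compound 3 `O=C(Cn1cnc2scc(-c3ccc4ccccc4c3)c2c1=O)N/N=C/c1ccc(Cl)c([N+](=O)[O-])c1` differs from compound 2 by naphthalen-2-yl in place of phenyl on an aromatic carbon. Among the compounds with values here, no measured step involves a change of this kind at this position; the single step available, on the same phenyl, was small. On that basis compound 3 is expected to give 16000 nM, within a range of 6000 nM to 40000 nM. The step this estimate implies, no change at the digits printed from compound 2 to compound 3 (within the scatter), is expected to stay near the scatter.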

Compound 3, half-maximal inhibitory concentration: 13000 nM
The estimate for compound 3 lay 1.2-fold (0.09 log units) above the measured number; the measured number falls inside the stated range.
By their numbers in this assay, from the lowest: compounds 3, 2 and 1 (each within the scatter of the next).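

Going by these compounds alone, earlier, the only change at this position was a chloro on the phenyl; now the whole aryl group grows from phenyl to naphthalen-2-yl, and this assay shows a 1.2-fold lower number from compound 2 to compound 3 (0.09 log units; within the scatter) as the result. Set against the 4-chlorophenyl group, naphthalen-2-yl gives a 1.5-fold lower number from compound 1 to compound 3 (0.19 log units; within the scatter), so all three aryl groups on the shared core stay within the scatter of one another, and this size change at this position leaves the read-out without a resolved shift. No supporting data are available to explain this flat result.

All three groups here are carbon-only aromatic rings, with or without chloro. From the compounds shown here alone, whether a ring carrying an amine or a carboxylic acid, or a pyridinyl ring, at this position would move the number beyond the scatter remains open.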